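The source may hold more compounds than are shown below. What is called first, only, known or untested is meant among the compounds shown, and "the series" means these compounds.

Measured so far:
compound 1 `CCCC(C1CC1)n1c(=O)c(C)nc2c(-c3ccc(Cl)cc3Cl)ccnc21`: 4.3 nM
compound 2 `CCC(COC)n1c(=O)c(C)nc2c(-c3cc(F)c(OC)cc3Cl)ccnc21`: 2.1 nM
compound 3 `CC[C@H](C1CC1)n1c(=O)c(C)nc2c(-c3ccc(OC)nc3C)ccnc21`: 76 nM

In a functional assay for antagonist activity at corticotropin-releasing factor receptor 1 (Rattus norvegicus) (a higher number here means a weaker inhibitor, a lower number a stronger inhibitor), compound 1 gives 4.3 nM and stands second highest of the three numbers. Compound 2 is its nearest neighbour, with a lower number that lies beyond the scatter; compound 3 is furthest away, with a much higher number, also beyond the scatter. Going by the values given here, no single-change step between measured compounds is available in this set.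

Compound 4 `CC[C@@H](COC)n1c(=O)c(C)nc2c(-c3ccc(Cl)cc3Cl)ccnc21` is derived from compound 1 by the change (1-(methoxymethyl)propyl in place of 1-cyclopropylbutyl on an aromatic nitrogen), with the aryl group of compound 1 retained. The same kind of side chain, though without defined stereochemistry, is present in compound 2, which gives 2.1 nM on a different aryl group, so the chain itself is compatible with strong inhibition in this assay. The step expected from compound 1 to compound 4 is therefore small, a 1.2-fold higher number from compound 1 to compound 4 (0.07 log units; within the scatter), and may well fall within the scatter, with no direction firmly indicated. Compound 4 is estimated at 5 nM, with a range from 2 nM to 15 nM.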

Compound 4, half-maximal inhibitory concentration: 74 nM
Compound 4: the middle estimate sits 15-fold (1.17 log units) below what was measured; measured number above the stated range.
By their numbers in this assay, from the lowest: compound 2; then compound 1; then compounds 4 and 3 (each within the scatter of the next).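

In this assay, the substituent on this aromatic nitrogen strongly affects inhibition when the aryl group of compound 1 is kept: 1-(methoxymethyl)propyl in place of 1-cyclopropylbutyl gives a 17-fold higher number from compound 1 to compound 4 (1.24 log units; beyond the scatter). On this aryl group, the entering chain, which has an oxygen, a defined stereocentre and no ring, therefore does not retain the inhibition seen with the leaving chain. Nothing available bears on the reason for this large step.

Going by these compounds alone, the single step does not separate the contributions of the lost three-membered ring, the shorter chain, the added oxygen and the defined stereocentre. Also open, from the compounds shown here alone, is where a 1-(ethoxymethyl)propyl or 1-(hydroxymethyl)propyl chain at this nitrogen, on the same aryl group, would fall relative to compound 1 and compound 4.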